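The source may hold more compounds than are shown below. What is called first, only, known or untested is meant among the compounds shown, and "the series" means these compounds.

Measured so far in an ADME assay on KB cells (Homo sapiens) for cytotoxicity, read by MTT assay, with a stated time of 72 h; a lower number here means that less compound is tolerated, a higher number that more compound is tolerated
compound 1 `Clc1ccc(Nc2nc(-c3ccccn3)cs2)nc1` gives 98600 nM
compound 2 `COc1ccnc(-c2csc(Nc3ccc(Cl)cn3)n2)c1` gives 62800 nM
compound 3 `CCOc1ccc(-c2csc(Nc3ccc(Cl)cn3)n2)nc1` gives 2700 nM

Compound 2 stands at 62800 nM in the upper part of this small set, within the scatter of compound 1 and well above compound 3. Compound 4 `COc1ccnc(-c2nc(Nc3ccc(Cl)cn3)sc2Cl)c1` is the next case and carries chloro in place of hydrogen on an aromatic carbon on the frame of compound 2. For the measured compounds named here, no measured step places chloro on this carbon next to the ring sulfur, so the evidence is indirect. Two steps, each a replacement of hydrogen on an aromatic carbon, bear on it loosely. These are a 1.6-fold lower number from compound 1 to compound 2 (0.20 log units; within the scatter) for methoxy and a 37-fold lower number from compound 1 to compound 3 (1.56 log units; beyond the scatter) for ethoxy. One stays within the scatter and the other is large, so a moderate fall in this assay is expected, with wide uncertainty. The expected step is a 2.5-fold lower number from compound 2 to compound 4 (0.40 log units; beyond the scatter) on this estimate. For compound 4 the estimated value is 25000 nM with an expected range of 6000 nM to 80000 nM.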

Compound 4, half-maximal cytotoxic concentration: 15000 nM
Beside the measured number, compound 4's estimate is 1.7-fold (0.22 log units) above it; the range from low to high includes it.
By their numbers in this assay, from the lowest: compound 3; then compound 4; then compounds 2 and 1 (each within the scatter of the next).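

In this assay, for the compounds shown here, chloro in place of hydrogen on the aromatic carbon next to the ring sulfur gives a 4.2-fold lower number from compound 2 to compound 4 (0.62 log units; beyond the scatter), and this is the first step measured at this position. The earlier steps shown here changed a different part of the core, so this result adds that a single chlorine atom on this carbon moves the number beyond the scatter, although the step is only modest. Nothing measured on these compounds accounts for the change in the number at this position.

Only chloro is shown on this carbon, so it remains open whether a methyl, a nitrile, an amine or a carboxylic acid there would give a similar step. Going by these compounds, it is also open whether chloro on this carbon would give a step of this size on the frame of compound 1 or compound 3.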